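Three Amide Analogues Sit at the Cytotoxicity Limit

This account rests on a few compounds, and the source may have more. Where it says the series, first, only, none or still open, it means among the compounds named here.

Compound 1, `Cc1ccc(NC(=O)c2cccc(/C=C3\CC(=O)N(c4ccccc4)C3=O)c2)cc1C`: > 100000 nM
Compound 2, `CCc1cccc(NC(=O)c2cccc(/C=C3\CC(=O)N(c4ccccc4)C3=O)c2)c1`: > 100000 nM
Compound 3, `O=C(NCc1ccccc1)c1cccc(/C=C2\CC(=O)N(c3ccccc3)C2=O)c1`: > 100000 nM

In an ADME assay on NCM460 cells (Homo sapiens) for cytotoxicity, read by MTT assay, with a stated time of 72 h (on this read-out higher numbers stand for weaker inhibition and lower numbers for stronger inhibition), compound 3 reaches only a limit of the assay, > 100000 nM, not a number. The two other compounds stand the same way, as the limit of > 100000 nM in this assay, at which 3 of the 3 values shown sit, records. The steps among them, a step that the two limits leave unreadable from compound 1 to compound 2, a step that the two limits leave unreadable from compound 1 to compound 3 and a step that the two limits leave unreadable from compound 2 to compound 3, therefore cannot be read for size, and nothing among the three separates one substituent on the amide-type nitrogen from another.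

Compound 4, `CSc1cccc(NC(=O)c2cccc(/C=C3\CC(=O)N(c4ccccc4)C3=O)c2)c1`, changes the group on that nitrogen: 3-(methylsulfanyl)phenyl in place of benzyl on an amide-type nitrogen. The measured steps that bear on it are the two that also alter this position in compound 3, from compound 1 and from compound 2, and both are unreadable. With every measured value at the limit, no direction and no size beyond the scatter can be drawn for this assay, and the expectation is that compound 4 also ends at the limit.

The estimate for compound 4 is accordingly 200000 nM, with a range from 60000 nM to 1000000 nM, which is expected to mean a step that the limit leaves unreadable from compound 3 to compound 4.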

Compound 4, half-maximal inhibitory concentration: > 100000 nM
Compound 4 gave a limit, no number; the forecaster's own chance of this, stated with the estimate: 85%; the middle value does not contradict the limit.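

In this assay, no step from compound 1, compound 2 or compound 3 to compound 4 can be read for size, because all four compounds rest on the same record: the limit of > 100000 nM in this assay, at which 4 of the 4 values shown sit.

The compounds shown leave open how large any of these values really is, and whether any group on the amide-type nitrogen would give a measurable number.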